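The source may hold more compounds than are shown below. What is called first, only, known or untested is meant among the compounds shown, and "the series" means these compounds.

Compound 1 `COc1cc2ncnc(NNC(=S)NC(=O)c3ccc(C)cc3)c2cc1OC` and compound 2 `COc1cc2ncnc(NNC(=S)NC(=O)c3ccc(C(F)(F)F)cc3)c2cc1OC` share one core, while compound 3 `O=C(NC(=S)NNc1ncnc2ccccc12)c1ccc(C(F)(F)F)cc1` and compound 4 `Cc1ccc(C(=O)NC(=S)NNc2ncnc3ccccc23)cc1` share another; the difference between the two cores is not broken down here. In a functional assay on KB cells (Homo sapiens) for cytotoxicity, read by MTT assay, with a stated time of 72 h (on this read-out lower numbers stand for stronger inhibition and higher numbers for weaker inhibition), compound 1 gives 24200 nM and compound 2 gives 8840 nM. Compound 1 differs from compound 2 by methyl in place of trifluoromethyl on an aromatic carbon, and this change brought a 2.7-fold higher number from compound 2 to compound 1 (0.44 log units; beyond the scatter). In this assay compound 3 gives 7920 nM, which lies within the scatter of compound 2. Compound 4 differs from compound 3 by methyl in place of trifluoromethyl on an aromatic carbon, the same change at the same place on a different core. Because the earlier change gave a 2.7-fold higher number from compound 2 to compound 1 (0.44 log units; beyond the scatter), a step of about that size is expected here, namely a 2.5-fold higher number from compound 3 to compound 4 (0.40 log units; beyond the scatter). Compound 4 is therefore estimated at 20000 nM, most likely between 9000 nM and 45000 nM.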

Compound 4, half-maximal inhibitory concentration: 10100 nM
Estimate against measurement, compound 4: 2.0-fold (0.30 log units) above, and the stated range covers the measured number.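

In this assay the same swap of trifluoromethyl for methyl on the second core gave a 1.3-fold higher number from compound 3 to compound 4 (0.11 log units; within the scatter) and so no change that can be told from scatter. The two steps cannot be told apart, so the swap may act alike on both cores, but this is not proven: the same change on two cores in this assay, a 2.7-fold higher number (0.44 log units; beyond the scatter) from compound 2 to compound 1 and a 1.3-fold higher number (0.11 log units; within the scatter) from compound 3 to compound 4, 2.1-fold (0.33 log units) apart, within the scatter of two such steps. Going by these compounds alone, with only two pairs, one step beyond the scatter and one within it, these numbers cannot predict the size of the step on a further core.

From the compounds shown here alone, it remains open how other groups at the same place, such as chlorine, an amine or a carboxylic acid, would compare with methyl and trifluoromethyl. Also open, going by these compounds, is whether the two cores would respond alike to those groups.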